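A few compounds are considered here, and "the series" means these few. Any claim that something is new, unique, unknown or untested is made for them only; others in the source may bear on it.

For the measured compounds named here, in a functional assay on RPTEC cells (Homo sapiens) for antiproliferative activity (a higher number here means a weaker inhibitor of growth, a lower number a stronger inhibitor of growth), compound 3 `c1ccc(-c2cc(-c3cccs3)cc(-c3ccccn3)n2)nc1` gives 0.0016 ug/mL, the lowest of the three numbers measured so far, against compound 2 `c1ccc(-c2cc(-c3ccccn3)nc(-c3ccccn3)c2)cc1` at 0.027 ug/mL and compound 1 `c1ccc(-c2cc(-c3cccnc3)nc(-c3ccccn3)c2)cc1` at 0.36 ug/mL. Compound 4 `c1ccc(-c2cc(-c3cccs3)cc(-c3cccnc3)n2)nc1` has the same atoms as compound 3, joined differently: pyridin-3-yl in place of pyridin-2-yl on an aromatic carbon. Pyridin-3-yl replaces pyridin-2-yl on an aromatic carbon. The most relevant measured change is this swap in reverse: a 13-fold lower number from compound 1 to compound 2 (1.12 log units; beyond the scatter). The other step, a 17-fold lower number from compound 2 to compound 3 (1.23 log units; beyond the scatter), introduced thiophen-2-yl, which compound 4 keeps. As far as these compounds go, a large move to a higher number, meaning weaker growth inhibition, is therefore expected in this assay, though this swap is untested alongside thiophen-2-yl. The expected step is a 13-fold higher number from compound 3 to compound 4 (1.10 log units; beyond the scatter). For compound 4 the estimated value is 0.02 ug/mL, with an expected range of 0.005 ug/mL to 0.08 ug/mL.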

Compound 4, concentration for 50% growth inhibition: 0.056 ug/mL
The estimate for compound 4 lay 2.8-fold (0.45 log units) below the measured number, and the stated range covers the measured number.
By their numbers in this assay, from the lowest: compound 3; then compound 2; then compound 4; then compound 1.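

Pyridin-3-yl in place of pyridin-2-yl raises the number on a second core as well, with a 35-fold higher number from compound 3 to compound 4 (1.54 log units; beyond the scatter), so the preference for pyridin-2-yl at this position in this assay no longer rests on one pair: the same change on two cores in this assay, a 13-fold lower number (1.12 log units; beyond the scatter) from compound 1 to compound 2 and a 35-fold lower number (1.54 log units; beyond the scatter) from compound 4 to compound 3, 2.6-fold (0.42 log units) apart, within the scatter of two such steps. Thiophen-2-yl in place of phenyl also lowers the number when pyridin-3-yl is present, with a 6.4-fold lower number from compound 1 to compound 4 (0.81 log units; beyond the scatter), so that gain does not depend on pyridin-2-yl: the same change on two cores in this assay, a 17-fold lower number (1.23 log units; beyond the scatter) from compound 2 to compound 3 and a 6.4-fold lower number (0.81 log units; beyond the scatter) from compound 1 to compound 4, 2.6-fold (0.42 log units) apart, within the scatter of two such steps.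

The compounds shown leave open whether pyridin-4-yl at this position would give a number closer to that of pyridin-2-yl or pyridin-3-yl. They also leave open how an amine or a carboxylic acid on that ring would change growth inhibition.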